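This account rests on a few compounds, and the source may have more. Where it says the series, first, only, none or still open, it means among the compounds named here.

Working notes on the series, read in a functional assay on MCF7 cells (Homo sapiens) for inhibition, with a stated time of 72 h; on this read-out higher numbers stand for weaker inhibition and lower numbers for stronger inhibition. Compound 1 `NC1CCC(Nc2nc(NCc3ccc(Br)cc3)c3ncn(C4CCCC4)c3n2)CC1` gives 850 nM, compound 3 `NC1CCC(Nc2nc(NCc3ccc(-n4cccn4)cc3)c3ncn(C4CCCC4)c3n2)CC1` gives 139 nM and compound 2 `NC1CCC(Nc2nc(NCc3ccc(-c4ccco4)cc3)c3ncn(C4CCCC4)c3n2)CC1` gives 85 nM. That last number is the lowest of the three, but it is separated only from compound 1 beyond the scatter.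

Compound 4 `NC1CCC(Nc2nc(NCc3ccc(-c4cccs4)nc3)c3ncn(C4CCCC4)c3n2)CC1` is not yet measured. It carries 6-(thiophen-2-yl)pyridin-3-yl in place of 4-(furan-2-yl)phenyl, a change from compound 2 counted as 6-(thiophen-2-yl)pyridin-3-yl in place of 4-(furan-2-yl)phenyl on a saturated chain carbon bound to a nitrogen on an aromatic ring.

Replacing bromo with an aromatic ring gave two steps beyond the scatter: a 10-fold lower number from compound 1 to compound 2 (1.00 log units; beyond the scatter) and a 6.1-fold lower number from compound 1 to compound 3 (0.79 log units; beyond the scatter). The closer precedent is the exchange of furan-2-yl for 1H-pyrazol-1-yl, a 1.6-fold higher number from compound 2 to compound 3 (0.21 log units; within the scatter), which stays within the scatter. Among the measured compounds shown here, no measured compound carries thiophen-2-yl or pyridin-3-yl, so the range is kept wide.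

The expected change in this assay is none beyond the scatter, with an estimated 1.2-fold higher number from compound 2 to compound 4 (0.07 log units; within the scatter). For compound 4 the estimated value is 100 nM, with an expected range of 30 nM to 330 nM.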

Compound 4, half-maximal inhibitory concentration: 92 nM
The estimate for compound 4 lay 1.1-fold (0.04 log units) above the measured number; measured number inside the range.
By their numbers in this assay, from the lowest: compounds 2, 4 and 3 (each within the scatter of the next); then compound 1.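

In this assay, 6-(thiophen-2-yl)pyridin-3-yl changes both aromatic rings of 4-(furan-2-yl)phenyl at once, yet the result is a 1.1-fold higher number from compound 2 to compound 4 (0.03 log units; within the scatter), and against 4-(1H-pyrazol-1-yl)phenyl it is a 1.5-fold lower number from compound 3 to compound 4 (0.18 log units; within the scatter). The place therefore accepts a ring nitrogen in the six-membered ring together with a sulfur-containing five-membered ring, with no step beyond the scatter among these three compounds. The step from the bromo compound, a 9.2-fold lower number from compound 1 to compound 4 (0.97 log units; beyond the scatter), extends the separation already seen for compound 2 and compound 3 to a third group, and no compound shown goes against it. Nothing measured here bears on why these groups read alike.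

Pyridin-3-yl and thiophen-2-yl change together in compound 4, so their separate contributions remain open. Also open, from the compounds shown here alone, is how the number responds to an amine or a carboxylic acid in place of thiophen-2-yl.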